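Swapping the Pendant Aryl Group on a Six-Ring Core

This account rests on a few compounds, and the source may have more. Where it says the series, first, only, none or still open, it means among the compounds named here.

Of the compounds shown here, three sharing one fused core have been tested so far in a functional assay on HeLa cells (Homo sapiens) for cytotoxicity, read by MTT assay, with a stated time of 48 h; a lower number here means a stronger inhibitor, a higher number a weaker inhibitor. Compound 1 `Cc1nc2c3ccccc3ccc2c2nc3c(ccc4ccccc43)c(-c3ccccc3S)c12` gives 3190 nM. Compound 2 `Cc1ccc(-c2c3ccc4ccccc4c3nc3c2c(C)nc2c4ccccc4ccc32)cc1` gives 72200 nM, and compound 3 `Cc1nc2c3ccccc3ccc2c2nc3c(ccc4ccccc43)c(-c3cccc([N+](=O)[O-])c3)c12` gives 50700 nM. Compound 3 therefore sits second highest of the three numbers: the step of a 1.4-fold lower number from compound 2 to compound 3 (0.15 log units; within the scatter) is within the scatter, while the step of a 16-fold higher number from compound 1 to compound 3 (1.20 log units; beyond the scatter) is well beyond it. Only the change in the pendant aryl group separates these three.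

Compound 4 `Cc1nc2c3ccccc3ccc2c2nc3c(ccc4ccccc43)c(-c3cc(O)nc4ccccc34)c12` is not yet measured. It differs from compound 3 in one place: 2-hydroxyquinolin-4-yl in place of 3-nitrophenyl on an aromatic carbon. Among the measured compounds shown here, two measured steps bear on this kind of swap. The step of a 16-fold higher number from compound 1 to compound 3 (1.20 log units; beyond the scatter) shows that the pendant group can move the number a great deal, whereas a 1.4-fold lower number from compound 2 to compound 3 (0.15 log units; within the scatter) shows that not every replacement does. Since compound 1, with its 2-sulfanylphenyl, is the only one of the three to reach a low number, and compound 4 carries a different group again, a moderate step downward is expected, of about a 2.5-fold lower number from compound 3 to compound 4 (0.40 log units; beyond the scatter). Compound 4 is thus estimated at 20000 nM, with a likely range from 5000 nM to 80000 nM in this assay.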

Compound 4, half-maximal inhibitory concentration: 4880 nM
Compound 4: the middle estimate sits 4.1-fold (0.61 log units) above what was measured; the whole stated range lies above it.
By their numbers in this assay, from the lowest: compounds 1 and 4 (each within the scatter of the next); then compounds 3 and 2 (each within the scatter of the next).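

In this assay, the swap at this aromatic carbon, opposite the ring nitrogen, gives a 10-fold lower number from compound 3 to compound 4 (1.02 log units; beyond the scatter) and the matching comparison gives a 15-fold lower number from compound 2 to compound 4 (1.17 log units; beyond the scatter), so a second pendant group now stands apart from those of compound 2 and compound 3. The step of a 1.5-fold higher number from compound 1 to compound 4 (0.18 log units; within the scatter) lies within the scatter, which places the 2-hydroxyquinolin-4-yl of compound 4 level with the 2-sulfanylphenyl of compound 1, and the low numbers at this position are therefore not tied to that one group. Compared with 3-nitrophenyl, the entering group brings a second six-membered aromatic ring, this one holding a nitrogen, and a hydrogen-bond donor, and it lacks the double bond outside aromatic rings, but this single step cannot separate these differences.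

Nothing at hand explains why these two groups stand apart from the others. The compounds shown leave open whether a quinolin-4-yl without the hydroxyl, or a phenyl ring carrying an amine or a carboxylic acid, would give a number near those of compound 1 and compound 4 or near those of compound 2 and compound 3.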